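Adding a side chain to a triazene nitrogen

This account rests on a few compounds, and the source may have more. Where it says the series, first, only, none or still open, it means among the compounds named here.

Measured in an ADME assay on Vero cells (Chlorocebus sabaeus) for cytotoxicity, read by crystal violet staining; on this read-out lower numbers stand for higher toxicity in this test and higher numbers for lower toxicity in this test:
- compound 1 `Clc1cccc(/N=N/N2CCCCC2)c1`: > 100000 nM
- compound 2 `Fc1ccc(F)c(/N=N/Nc2ccccc2)c1`: 80000 nM
- compound 3 `Fc1ccc(F)c(/N=N/Nc2cccc(C(F)(F)F)c2)c1`: 80000 nM

Compound 2 stands level with compound 3 at the digits shown. Compound 1 reports only a limit of the assay, > 100000 nM, and not a number, so it gives no exact point of comparison.

The next compound to be tested is compound 4 `CN(C)CCCN(/N=N/c1cc(F)ccc1F)c1ccccc1`. Its difference from compound 2 is this: 3-(dimethylamino)propyl in place of hydrogen on a nitrogen on an aromatic ring. The new group sits on a nitrogen, replacing the hydrogen there.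

For the measured compounds named here, the only measured step between two compounds is no change at the digits printed from compound 2 to compound 3 (within the scatter). That change, trifluoromethyl in place of hydrogen on an aromatic carbon, was made at a different kind of atom, so it is only a weak guide to what happens at the nitrogen. Going by the values given here, no measured step tests a change at that nitrogen.

A moderate step is expected in this assay, more likely towards lower numbers, which mean higher toxicity, since compound 2 at 80000 nM leaves little room upward. The expected step is a 1.8-fold lower number from compound 2 to compound 4 (0.25 log units; within the scatter), and this estimate is loose. For compound 4 the estimated value is 45000 nM, with an expected range of 15000 nM to 100000 nM.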

Compound 4, half-maximal cytotoxic concentration: 7000 nM
The estimate for compound 4 lay 6.4-fold (0.81 log units) above the measured number; the whole stated range lies above it.
By their numbers in this assay, from the lowest: compound 4; then compounds 2 and 3 (each within the scatter of the next). At a limit, above all of these: compound 1.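

The nitrogen on an aromatic ring turns out to be a position where this assay responds strongly: placing 3-(dimethylamino)propyl there in place of hydrogen gives an 11-fold lower number from compound 2 to compound 4 (1.06 log units; beyond the scatter), a large move towards higher toxicity in this test. For the compounds shown here, the earlier compounds could not show this, since their only measured step was made on an aromatic carbon, where trifluoromethyl in place of hydrogen gave no change at the digits printed from compound 2 to compound 3 (within the scatter). Of the two places changed on compound 2, then, only the nitrogen has so far moved the number beyond the scatter, although each place has been tested with just one group.

The compounds shown leave open whether this step belongs to the dimethylamino part, to the propyl chain or simply to the loss of the hydrogen on that nitrogen, and a plain methyl group, a longer chain or a chain ending in a carboxylic acid at the same nitrogen would help to separate these. Compound 1 gives no exact point of comparison, since it sits at a limit and not at a number: the limit of > 100000 nM in this assay, at which 1 of the 4 values shown sits.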